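The source may hold more compounds than are shown below. What is called first, only, known or untested is meant among the compounds shown, and "the series" means these compounds.

Compound 1, `CCCCCCc1cn(C(c2ccccc2)c2cc3cc(Br)ccc3nc2OC)nn1`, gives -3.17% in an ADME assay on HEK293 cells (Homo sapiens) for cytotoxicity, read by sulforhodamine B assay, with a stated time of 48 h, tested at 10 uM; on this read-out lower numbers stand for less inhibition and higher numbers for more inhibition at the one concentration tested (going by the name of the read-out).
Compound 2, `CCCc1cn(C(c2ccccc2)c2cc3cc(Br)ccc3nc2OC)nn1`, gives 0.85% in this assay.

Among the measured compounds shown here, on these two numbers compound 2 stands level with compound 1: the only measured step, a number 4 percentage points higher from compound 1 to compound 2 (within the scatter), is too small to tell the two apart, and both lie near zero, meaning neither compound does much to the cells at the concentration tested.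

Compound 3, `COc1nc2ccc(Br)cc2cc1C(c1ccccc1)n1cc(-c2cccc(F)c2)nn1`, differs from compound 2 in one place: 3-fluorophenyl in place of propyl on an aromatic carbon. For the measured compounds named here, the one measured step that bears on this spot, a number 4 percentage points higher from compound 1 to compound 2 (within the scatter), shows that shortening the chain at this position changed the read-out by no more than the scatter. Going by the values given here, no measured pair exchanges a chain for an aromatic ring here, so nothing in the data points to a step beyond the scatter in either direction. Compound 3 is therefore expected to sit close to compound 2, with the estimated step of a number 1.2 percentage points higher from compound 2 to compound 3 (within the scatter), giving an estimate of 2% with a range from -9% to 14%.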

Compound 3, a percentage reported as inhibition, at one concentration (the size of the read-out at that concentration, not a potency): 6.84%
The estimate for compound 3 lay 4.8 percentage points below the measured number, and the stated range covers the measured number.
By their numbers in this assay, from the lowest: compounds 1, 2 and 3 (each within the scatter of the next).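

Until now this position on the five-membered aromatic ring had been probed only with chains of different length. The result shows that a ring can stand there too: in this assay, 3-fluorophenyl in place of propyl gives one step (a number 6 percentage points higher from compound 2 to compound 3 (within the scatter)) and 3-fluorophenyl in place of hexyl gives another (a number 10 percentage points higher from compound 1 to compound 3 (within the scatter)), so neither swap from chain to ring separates the compounds. No measurement here offers a reason for these numbers.

From the compounds shown here alone, it remains open whether a plain phenyl, an amine or a carboxylic acid at this position would give a step beyond the scatter. A single concentration also leaves open how these compounds would behave on these cells at higher concentrations.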